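The source may hold more compounds than are shown below. What is called first, only, known or untested is meant among the compounds shown, and "the series" means these compounds.

Measured so far in a functional assay on PC-3 cells (Homo sapiens) for antiproliferative activity, read by MTT assay, with a stated time of 48 h; on this read-out higher numbers stand for weaker inhibition and lower numbers for stronger inhibition
- compound 1 `O=C(/C=C/c1ccc(O)cc1)Nc1cc2c(Nc3ccc(Cl)c(Cl)c3)ncnc2s1` gives 300 nM
- compound 2 `O=C(/C=C/c1ccccc1)Nc1cc2c(Nc3ccc(F)c(Cl)c3)ncnc2s1` gives 700 nM
- compound 3 `O=C(/C=C/c1ccccc1)Nc1cc2ncnc(Nc3cc(Cl)cc(Cl)c3)c2s1` gives 220 nM

Compound 2 stands highest of the three, with compound 1 and compound 3 both lower by more than the scatter. The change to compound 4 `C#Cc1cccc(Nc2ncnc3sc(NC(=O)/C=C/c4ccccc4)cc23)c1` is 3-ethynylphenyl in place of 3-chloro-4-fluorophenyl on a nitrogen on an aromatic ring and sits on a nitrogen on an aromatic ring. Within the data shown here, no pair of measured compounds differs in one place only, so no measured step guides this change. The expectation therefore rests on compound 2 (at 700 nM) and on the spread of the other two values. A small move towards stronger inhibition, not beyond the scatter, is expected, with the estimated 1.4-fold lower number from compound 2 to compound 4 (0.15 log units; within the scatter) as the working figure. For compound 4 the estimated value is 500 nM with an expected range from 150 nM to 1500 nM as working bounds.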

Compound 4, half-maximal inhibitory concentration: 400 nM
The estimate for compound 4 lay 1.3-fold (0.10 log units) above the measured number, within the range that was stated.
By their numbers in this assay, from the lowest: compounds 3, 1, 4 and 2 (each within the scatter of the next, the first and the last beyond it).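

In this assay, among these compounds, this is the first comparison that differs in one place only. Placing 3-ethynylphenyl instead of 3-chloro-4-fluorophenyl on the nitrogen gives a 1.8-fold lower number from compound 2 to compound 4 (0.24 log units; within the scatter), so the two groups are not told apart at this position, and an all-carbon group with a triple bond serves there as well as the halogenated one. No supporting evidence bears on this result.

Still open, from the compounds shown here alone, is how an amine or a carboxylic acid in place of the ethynyl group would read in this assay. The compounds shown also leave open whether an unsubstituted phenyl on that nitrogen would stand apart from these two groups.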